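Dechlorination of compound 1: expected cytotoxicity read-out

The compounds below may be only part of what the source reports. "The series", "measured", "known", "first", "only" and "open" are said of these compounds alone.

Compound 1 `CS(=O)(=O)CCCn1c(Cn2c(=O)n(C3CC3)c3ccncc32)cc2cc(Cl)ccc21` in an ADME assay on HeLa cells (Homo sapiens) for cytotoxicity, read by ATP content, with a stated time of 3 days (on this read-out higher numbers stand for lower toxicity in this test and lower numbers for higher toxicity in this test), gives > 50000 nM, which is a limit of the assay rather than a number. Compound 2 `CS(=O)(=O)CCCn1c(Cn2c(=O)[nH]c3ccncc32)cc2cc(Cl)ccc21` in this assay gives > 50000 nM, again a limit. Compound 3 `O=C(O)CCCn1c(Cn2c(=O)n(C3CC3)c3ccncc32)cc2cc(Cl)ccc21` in this assay gives > 50000 nM, also a limit. Compound 1 therefore stands where the limit of > 50000 nM in this assay, at which 3 of the 3 values shown sit, puts every value shown, and no ordering among compounds 1, 2 and 3 can be read from these numbers.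

The change under study leads to compound 4 `CS(=O)(=O)CCCn1c(Cn2c(=O)n(C3CC3)c3ccncc32)cc2ccccc21`: hydrogen in place of chloro on an aromatic carbon. The measured steps that start from compound 1 are a step that the two limits leave unreadable from compound 1 to compound 2 and a step that the two limits leave unreadable from compound 1 to compound 3; both end at the same limit, so neither has a readable size. Among the compounds with values here, neither step touches the chloro position, and no measured step does. The step from compound 1 to compound 4 is expected to be a number no higher from compound 1 to compound 4 (the limit leaves the size open), with the read-out most likely again returned as a limit, because compound 1 itself sits at the limit of > 50000 nM in this assay, at which 3 of the 3 values shown sit. Compound 4 in this assay is therefore estimated at 50000 nM. The lower end estimated for compound 4 is 20000 nM. The upper end estimated for compound 4 is 100000 nM.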

Compound 4, half-maximal cytotoxic concentration: > 100000 nM
Compound 4: only a limit was reported; the forecaster's own chance of this, stated with the estimate: 85%; middle value at least 2.0-fold (0.30 log units) away from the limit.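

Compound 4 gives > 100000 nM in this assay, which is a limit of the assay; compound 1 also sits at a limit, so the step between compound 1 and compound 4 cannot be read. The compounds shown leave open what effect, if any, hydrogen in place of chloro has on this read-out.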